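This account rests on a few compounds, and the source may have more. Where it says the series, first, only, none or still open, it means among the compounds named here.

Compound 1 `NC(=O)c1c(NC(=O)c2ccccc2Cl)sc2c1CCN(Cc1ccc([N+](=O)[O-])cc1)C2` carries a 4-nitrobenzyl group on the amine nitrogen in a ring of its shared core. In a functional assay on HL-60 cells (Homo sapiens) for antiproliferative activity, with a stated time of 24 h (a lower number here means a stronger inhibitor, a higher number a weaker inhibitor), compound 1 gives 11400 nM. Among the two plain numbers at hand this is the lowest, with compound 3 `NC(=O)c1c(NC(=O)c2ccc(C(F)(F)F)cc2)sc2c1CCN(Cc1ccc(Cl)cc1Cl)C2` nearest at 14900 nM, a gap that stays within the usual scatter of this kind of measurement. Compound 2 `NC(=O)c1c(NC(=O)c2ccc(C(F)(F)F)cc2)sc2c1CCN(Cc1ccc(Cl)cc1)C2` reaches only a limit of the measurement, > 50000 nM. Within the data shown here, the step of an at least 3.3-fold lower number from compound 2 to compound 3 (0.52 log units; beyond the scatter) is the one measured change in this set; it alters the ring hanging from that same amine nitrogen, and its size can be stated only against a limit, namely (the limit of > 50000 nM in this assay, at which 1 of the 3 values shown sits).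

Compound 4 `Cc1ccccc1NC(=S)N1CCc2c(sc(NC(=O)c3ccccc3Cl)c2C(N)=O)C1` differs from compound 1 in a group of 10 heavy atoms (8 carbon, 1 nitrogen, 1 sulfur; one six-membered aromatic ring of carbon only) in place of a group of 10 heavy atoms (7 carbon, 1 nitrogen, 2 oxygen; one six-membered aromatic ring of carbon only), on an amine nitrogen in a ring. Among the measured compounds shown here, no measured pair swaps the whole group on that nitrogen, so the step from compound 2 to compound 3 bears on it only in showing that what sits on this amine nitrogen can move the readout by a modest amount. For the measured compounds named here, with no closer precedent, the expected step of a 1.1-fold higher number from compound 1 to compound 4 (0.02 log units; within the scatter) is none beyond the scatter. Compound 4 is therefore estimated at 12000 nM, within a deliberately wide range from 3000 nM to 50000 nM.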

Compound 4, half-maximal inhibitory concentration: 22600 nM
Compound 4: middle estimate off by 1.9-fold (0.27 log units), on the low side; measured number inside the range.
By their numbers in this assay, from the lowest: compounds 1, 3 and 4 (each within the scatter of the next). At a limit, above all of these: compound 2.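

In this assay, the step of a 2.0-fold higher number from compound 1 to compound 4 (0.30 log units; within the scatter) lies within the scatter: exchanging 4-nitrobenzyl for a group with no common name, which has the same count of heavy atoms and also one six-membered aromatic ring of carbon only but adds a hydrogen-bond donor, gives no measurable change in this pair. Among these compounds, until now, the only measured change on this amine nitrogen's group was the gain of a chloro in the step of an at least 3.3-fold lower number from compound 2 to compound 3 (0.52 log units; beyond the scatter), whose size rests on a limit; the new step instead replaces the whole group, and both of its ends are plain numbers, showing that such a large exchange on this nitrogen can be tolerated in this assay. Nothing measured here says what either group does in the cells, and neither the shared ring nor the hydrogen-bond donor can be credited or blamed for this result.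

Still open, as far as these compounds go, is how the readout would respond if this nitrogen carried only hydrogen, a short alkyl chain or a benzyl group bearing a carboxylic acid. The compounds shown also leave unknown whether any group at this position could bring the number clearly beyond the scatter from that of compound 1.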